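The source may report more compounds than this note shows. Statements on the series, on what has been measured and on what is new or still open speak of the compounds shown alone.

Measured compounds:
compound 1 `COc1cc(C)cc(-c2c(-c3ccnc(-c4ccc(N(C)C)cc4)c3)cnn2CC#N)c1` — 98%
compound 2 `COc1cc(C)cc(-c2nn(CC#N)cc2-c2ccc(-c3cccc(C(C)=O)c3)nc2)c1` — 102%

Both were run in a functional assay on OVCAR-3 cells (Homo sapiens) for cytotoxicity, read by sulforhodamine B assay, with a stated time of 48 h, tested at 0.001 uM; a higher number here means a weaker effect of the compound at the concentration tested, a lower number a stronger effect. At the concentration used, compound 1 gives 98% and compound 2 gives 102%. The two numbers lie within the scatter of each other, so compound 1 stands level with compound 2, and neither number points to any measurable effect at this concentration.

Compound 3 `COc1cc(C)cc(-c2c(-c3ccnc(-c4ccc(C(C)=O)cc4)c3)cnn2CC#N)c1` is not yet measured. It differs from compound 1 in one place: acetyl in place of dimethylamino on an aromatic carbon. Among the compounds with values here, no pair of measured compounds shows the effect of this change, so its size cannot be read from the numbers at hand. Within the data shown here, with compound 1 at 98% and compound 2 at 102%, nothing measured so far shows any member of the series leaving the range of no effect at this concentration. Expected in this assay is a number 1 percentage points higher from compound 1 to compound 3 (within the scatter), a step of no size beyond the scatter in either direction. For compound 3 the estimated value is 99%, with a range from 88% to 110%.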

Compound 3, a percentage reported as activity, at one concentration (the size of the read-out at that concentration, not a potency): 103%
Beside the measured number, compound 3's estimate is 4 percentage points below it; measured number inside the range.
By their numbers in this assay, from the lowest: compounds 1, 2 and 3 (each within the scatter of the next).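

In this assay, acetyl in place of dimethylamino on an aromatic carbon, para to a large group, gives a number 5 percentage points higher from compound 1 to compound 3 (within the scatter). Within the data shown here, this is the first pair that differs in one place, so the change now has a measured size, and that size does not separate the 4-(dimethylamino)phenyl and 4-acetylphenyl forms at the single concentration tested, with both compounds remaining in the range of no effect. No supporting evidence bears on this result, and the pair itself gives no explanation for it.

As far as these compounds go, a single concentration at which compound 1 and compound 3 show no effect gives no potency for either, so it remains open whether the two groups would differ at concentrations where the series begins to show cytotoxicity. From the compounds shown here alone, it also remains open whether any other group at this position, such as a primary amine, a carboxylic acid or a longer alkyl chain, would bring a member of the series out of the range of no effect.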